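A few compounds are considered here, and "the series" means these few. Any claim that something is new, unique, unknown or untested is made for them only; others in the source may bear on it.

Measured so far in an in vitro ADME assay on microsomes from liver (Homo sapiens) for metabolic stability; on this read-out higher numbers stand for fast clearance and lower numbers for slow clearance

compound 1 `CC(C)NC(=O)[C@H]1CC[C@@H](n2/c(=N/C(=O)c3ccc(C#N)c(F)c3)[nH]c3ccc(CN4CCC(C(C)(C)O)CC4)cc32)CC1` gives 132 mL.min-1.g-1
compound 2 `CC(C)NC(=O)[C@H]1CC[C@@H](n2/c(=N/C(=O)c3cc(F)cc(Cl)c3)[nH]c3ccc(CN4CCC(C(C)(C)O)CC4)cc32)CC1` gives 83 mL.min-1.g-1

On these numbers, compound 2 cannot be told apart from compound 1. Going by the values given here, the only measured step is a 1.6-fold lower number from compound 1 to compound 2 (0.20 log units; within the scatter) and it concerns the same place on a carbonyl carbon.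

Compound 3 `CC(C)NC(=O)[C@H]1CC[C@@H](n2/c(=N/C(=O)c3cccc(C#N)c3)[nH]c3ccc(CN4CCC(C(C)(C)O)CC4)cc32)CC1` has 3-cyanophenyl in place of 3-chloro-5-fluorophenyl on a carbonyl carbon and otherwise matches compound 2. Like compound 1, it carries a cyano group on this ring, but only one measured step bears on the swap. That step, a 1.6-fold lower number from compound 1 to compound 2 (0.20 log units; within the scatter) as its size, gives no reason to expect a large shift. The change is therefore expected to stay within the scatter in this assay. Any small drift would lean towards compound 1 at 132 mL.min-1.g-1 on this read-out. The estimated step is a 1.2-fold higher number from compound 2 to compound 3 (0.08 log units; within the scatter) in size. For compound 3 the expected value is 100 mL.min-1.g-1 with an estimated range from 55 mL.min-1.g-1 to 180 mL.min-1.g-1 overall.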

Compound 3, intrinsic clearance in microsomes: 72 mL.min-1.g-1
Compound 3: the middle estimate sits 1.4-fold (0.14 log units) above what was measured, and the stated range covers the measured number.
By their numbers in this assay, from the lowest: compounds 3, 2 and 1 (each within the scatter of the next).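

In this assay, a third group on this carbonyl carbon still gives no step beyond the scatter: 3-cyanophenyl in place of 3-chloro-5-fluorophenyl gives a 1.2-fold lower number from compound 2 to compound 3 (0.06 log units; within the scatter), and 3-cyanophenyl in place of 4-cyano-3-fluorophenyl gives a 1.8-fold lower number from compound 1 to compound 3 (0.26 log units; within the scatter). The three substituted phenyl groups therefore cannot be told apart at this position, even though the nitrile is present in compound 1 and compound 3 and absent from compound 2. No supporting measurement is available to explain why these numbers stay so close.

Going by these compounds, all three groups are phenyl rings, so it remains open whether a pyridine or a cyclohexyl group on this carbonyl carbon would shift the number beyond the scatter. The same question stands for a phenyl ring carrying an amine or a carboxylic acid.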